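Acetyl to oxime on the anilide ring of compound 3

The compounds below may be only part of what the source reports. "The series", "measured", "known", "first", "only" and "open" are said of these compounds alone.

Compound 1 `CCOc1ccc(Br)cc1-c1cc(Nc2ccc(C(N)=O)cc2)nc(N)n1`: 750 nM
Compound 2 `CCOc1ccc(Br)cc1-c1cc(Nc2ccc(C(=O)NO)cc2)nc(N)n1`: 88 nM
Compound 3 `CCOc1ccc(Br)cc1-c1cc(Nc2ccc(C(C)=O)cc2)nc(N)n1`: 34 nM

In an assay on Sf9 cells for inhibition of 1-acyl-sn-glycerol-3-phosphate acyltransferase beta (Homo sapiens) (a lower number here means a stronger inhibitor, a higher number a weaker inhibitor), compound 3 gives the lowest number of the three, with compound 2 next and compound 1 furthest away. Compound 4 `CCOc1ccc(Br)cc1-c1cc(Nc2ccc(/C(C)=N\O)cc2)nc(N)n1` differs from compound 3 by a group of 4 heavy atoms (2 carbon, 1 nitrogen, 1 oxygen; no ring) in place of a group of 3 heavy atoms (2 carbon, 1 oxygen; no ring), on an aromatic carbon, that is, a group of 4 heavy atoms in place of a group of 3 heavy atoms, on an aromatic carbon. Among the measured compounds shown here, two steps bear on this: an 8.5-fold lower number from compound 1 to compound 2 (0.93 log units; beyond the scatter) shows that adding a hydroxy to a nitrogen on this side helped, while a 2.6-fold lower number from compound 2 to compound 3 (0.41 log units; beyond the scatter) shows that the bare acetyl did better still. Taken together, compound 4 is expected to stay near compound 3, with a 1.5-fold higher number from compound 3 to compound 4 (0.17 log units; within the scatter) likely within the scatter. Compound 4 is therefore estimated at 50 nM, in the range 15 nM to 170 nM.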

Compound 4, half-maximal inhibitory concentration: 84 nM
For compound 4 the middle estimate is 1.7-fold (0.23 log units) below the measured one; measured number inside the range.
By their numbers in this assay, from the lowest: compound 3; then compounds 4 and 2 (each within the scatter of the next); then compound 1.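

In this assay the oxime gives back ground against the acetyl (a 2.5-fold higher number from compound 3 to compound 4 (0.39 log units; beyond the scatter)), yet it keeps a clear advantage over the plain amide (an 8.9-fold lower number from compound 1 to compound 4 (0.95 log units; beyond the scatter)) and cannot be told apart from the hydroxyamino carbonyl group (a 1.0-fold lower number from compound 2 to compound 4 (0.02 log units; within the scatter)). Nothing measured here explains these differences. The compounds shown leave open how a carboxylic acid, a methyl ester or a propanoyl group would fare on this aromatic carbon. They also leave open whether the methyl ether of the oxime or its other geometric form would match the acetyl.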